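Adding a Pyridinylcarbonyl Group to Compound 2

This account rests on a few compounds, and the source may have more. Where it says the series, first, only, none or still open, it means among the compounds named here.

In a functional assay (aorta) with Rattus norvegicus as the target (a lower number here means that less compound is needed, a higher number that more compound is needed for the effect), compound 1 (`C/N=C(/NC)Nc1nc(-c2ccc(OC)cc2)c(-c2ccc(OC)cc2)s1`) gives 2.4 uM and compound 2 (`COc1ccc(-c2nc(CN)sc2-c2ccc(OC)cc2)cc1`) gives 7.7 uM as the higher of the two numbers. Compound 3 (`COc1ccc(-c2nc(CNC(=O)c3cccnc3)sc2-c2ccc(OC)cc2)cc1`) has not yet been measured. Its structural change from compound 2 is (pyridin-3-yl)carbonyl in place of hydrogen on an amine nitrogen so that aminomethyl becomes (((pyridin-3-yl)carbonyl)amino)methyl.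

Going by the values given here, only one measured step bears on this change, and only loosely. The modest 3.2-fold higher number from compound 1 to compound 2 (0.51 log units; beyond the scatter) lies beyond the scatter, but it exchanges one whole group for another on an aromatic carbon and does not add anything to an amine nitrogen. Among the compounds with values here, no measured compound carries (pyridin-3-yl)carbonyl, so the data give no firm direction. Within the data shown here, with the modest size of a 3.2-fold higher number from compound 1 to compound 2 (0.51 log units; beyond the scatter) as the only guide, a large change in this assay is not expected. The expected 1.5-fold lower number from compound 2 to compound 3 (0.19 log units; within the scatter) is therefore small, with a slight lean towards a lower number and wide uncertainty in both directions. For compound 3 the estimate is 5 uM with an expected range from 1.2 uM to 20 uM in this measurement.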

Compound 3, concentration for half-maximal effect: 8.2 uM
Compound 3: the middle estimate sits 1.6-fold (0.21 log units) below what was measured; the range from low to high includes it.
By their numbers in this assay, from the lowest: compound 1; then compounds 2 and 3 (each within the scatter of the next).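

Going by these compounds alone, on the amine nitrogen of the aminomethyl group, (pyridin-3-yl)carbonyl in place of hydrogen leaves this assay without a change beyond the scatter, with a 1.1-fold higher number from compound 2 to compound 3 (0.03 log units; within the scatter) as the step, so a group of this size, with its six-membered aromatic ring and its carbonyl, can stand here with no measurable shift; the only earlier step exchanged whole groups on an aromatic carbon and could not show this. The gap to compound 1 stays as it was, with a 3.4-fold higher number from compound 1 to compound 3 (0.53 log units; beyond the scatter) as the step, so acylating this amine does not close that gap, and compound 1 keeps the lowest number of the three. No measured evidence is at hand that would account for the flat step.

The compounds shown leave open whether the nitrogen of the pyridine ring plays any part here, which benzoyl or a pyridin-4-yl carbonyl group would test, and whether a small acetyl group behaves the same way. They also leave open whether a longer chain in place of aminomethyl, or a second methyl on the amine, would move the number towards that of compound 1.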